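Moving the methyl around the pyridinyl ether and solubility

A few compounds are considered here, and "the series" means these few. Any claim that something is new, unique, unknown or untested is made for them only; others in the source may bear on it.

Measured compounds and their solubility:
compound 1, `Cn1c(COc2cccc(C(=O)O)c2)nc2ccc(Oc3ccccn3)cc21`: 62 ug/mL
compound 2, `Cc1cccc(Oc2ccc3nc(COc4cccc(C(=O)O)c4)n(C)c3c2)n1`: 92 ug/mL
compound 3, `Cc1ccnc(Oc2ccc3nc(COc4cccc(C(=O)O)c4)n(C)c3c2)c1`: 33 ug/mL

Of the compounds shown here, three sharing one core have been measured in a physicochemical assay for solubility, read by HPLC, measured as thermodynamic solubility, with a stated time of 4 h, at pH 6.8; a higher number here means a more soluble compound, a lower number a less soluble compound. Compound 3 has the lowest number of the three, though its gap to compound 1 is within the scatter and only its gap to compound 2 is beyond it, as the step of a 2.8-fold lower number from compound 2 to compound 3 (0.45 log units; beyond the scatter) shows. Compound 4, `Cc1cccnc1Oc1ccc2nc(COc3cccc(C(=O)O)c3)n(C)c2c1`, has not yet been measured. It differs from compound 3 in one place: 3-methylpyridin-2-yl in place of 4-methylpyridin-2-yl on an oxygen on an aromatic ring.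

The measured steps that bear on this are those that move or add a methyl on the same pyridinyl ring. The step of a 1.5-fold higher number from compound 1 to compound 2 (0.17 log units; within the scatter) and the step of a 1.9-fold lower number from compound 1 to compound 3 (0.27 log units; within the scatter) each stayed within the scatter, while the step of a 2.8-fold lower number from compound 2 to compound 3 (0.45 log units; beyond the scatter) was modest. So shifting the methyl between positions on this ring has so far given at most a modest change in either direction. For compound 4 no step beyond the scatter is therefore expected from compound 3, the estimated step being a 1.5-fold higher number from compound 3 to compound 4 (0.18 log units; within the scatter). Compound 4 is expected to show 50 ug/mL in this assay, with a range from 22 ug/mL to 115 ug/mL.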

Compound 4, solubility: 37 ug/mL
Compound 4: middle estimate off by 1.4-fold (0.13 log units), on the high side; low and high end bracket the measured number.
By their numbers in this assay, from the lowest: compounds 3, 4, 1 and 2 (each within the scatter of the next, the first and the last beyond it).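

In this assay, moving the methyl to give the 3-methylpyridin-2-yl group in place of the 4-methylpyridin-2-yl group on this oxygen leaves the reading within the scatter, with a 1.1-fold higher number from compound 3 to compound 4 (0.05 log units; within the scatter) as the step, and the methyl in place of hydrogen on an aromatic carbon also stays within it, with a 1.7-fold lower number from compound 1 to compound 4 (0.22 log units; within the scatter) as the step. Among these compounds, the only step beyond the scatter that this result adds is a 2.5-fold lower number from compound 2 to compound 4 (0.40 log units; beyond the scatter), a modest one, so compound 2 with its 6-methylpyridin-2-yl group now stands apart from two other methyl placements, although its own step from compound 1 remains within the scatter. Nothing measured here accounts for these differences.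

The compounds shown leave open whether a group other than methyl on this ring, such as a methoxy group, a fluorine or an amine, would take the reading beyond the scatter from compound 1. They also leave open whether the gap between compound 2 and compounds 3 and 4 would persist if a tetrazole replaced the carboxylic acid on the shared core.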